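The source may hold more compounds than are shown below. What is called first, only, known or untested is meant among the compounds shown, and "the series" means these compounds.

In an assay on isolated protein for inhibition of protein deacetylase HDAC6 (Homo sapiens), read by fluorescence, with stated times of 3 h and 60 min (a lower number here means a stronger inhibitor, a higher number a weaker inhibitor), compound 1 `Nc1ccccc1NC(=O)c1ccc(CNC2=N[C@@H](Cc3ccccc3)CS2)cc1` gives > 20000 nM, which is a limit of the assay rather than a number. Compound 2 `Nc1ccccc1NC(=O)c1ccc(CNC2=NC(=O)C(Cc3c[nH]c4ccccc34)N2)cc1` likewise returns > 20000 nM, again a limit. Compound 3 `Nc1cc(-c2ccccc2)ccc1NC(=O)c1ccc(CNc2nccc(-c3cccnc3)n2)cc1` also gives > 20000 nM, a limit of the assay and not a measured number. Compound 3 thus stands where every value shown stands, because of the limit of > 20000 nM in this assay, at which 3 of the 3 values shown sit. Compound 4 `CC(C)(C)[Si](C)(C)OCc1ccc(NC(=O)c2ccc(CNc3nccc(-c4cccnc4)n3)cc2)c(N)c1` differs from compound 3 by a group of 9 heavy atoms (7 carbon, 1 oxygen, 1 silicon; no ring) in place of a group of 6 heavy atoms (6 carbon; one six-membered aromatic ring of carbon only), on an aromatic carbon, on an aromatic carbon, meta to an amino group and para to a large group. Going by the values given here, no step between measured compounds is known, and every measured value is a limit, so no shift beyond the scatter is expected. The expected change is a number no higher from compound 3 to compound 4 (the limit leaves the size open). Compound 4 is therefore estimated at 20000 nM, with a range of 8000 nM to 50000 nM.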

Compound 4, half-maximal inhibitory concentration: > 20000 nM
Compound 4 ended at the assay's limit; the forecaster's own chance of this, stated with the estimate: 80%; the middle value sits exactly at the limit.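

Compound 3 and compound 4 both stand at a limit rather than a number, so no step can be read between them: the limit of > 20000 nM in this assay, at which 4 of the 4 values shown sit.

The compounds shown leave open how strongly any of them inhibits, and whether replacing phenyl changes that at all.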